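Removing One Methoxy Group: an Expected Small Step

This account rests on a few compounds, and the source may have more. Where it says the series, first, only, none or still open, it means among the compounds named here.

Compound 1 `COc1cc(-c2cc(/C=C/C(=O)c3ccc(N)cc3)[nH]n2)cc(OC)c1OC` gives 92% in a functional assay on NCI-H522 cells (Homo sapiens) for cytotoxicity, read by sulforhodamine B assay, with a stated time of 48 h, tested at 0.01 uM; on this read-out lower numbers stand for a stronger effect and higher numbers for a weaker effect at the one concentration tested. Compound 2 `COc1ccc(C(=O)/C=C/c2cc(-c3cc(OC)c(OC)c(OC)c3)n[nH]2)cc1OC` gives 83% in this assay; the difference between its core and that of compound 1 is 4-aminophenyl in place of 3,4-dimethoxyphenyl on a carbonyl carbon, and the step is a number 9 percentage points lower from compound 1 to compound 2 (within the scatter). Compound 3 `COc1ccc(C(=O)/C=C/c2cc(-c3cc(OC)c(OC)c(OC)c3)n[nH]2)cc1` gives 83% in this assay, with a number 9 percentage points lower from compound 1 to compound 3 (within the scatter). From compound 2 to compound 3 the change is hydrogen in place of methoxy on an aromatic carbon, and it made no change at the digits printed from compound 2 to compound 3 (within the scatter). Compound 4 `COc1ccc(-c2cc(/C=C/C(=O)c3ccc(N)cc3)[nH]n2)cc1OC` is not yet measured; it differs from compound 1 by hydrogen in place of methoxy on an aromatic carbon. This is the same kind of change, though here the place is also meta to a methoxy group. For compound 4 the expected step is a number 2 percentage points lower from compound 1 to compound 4 (within the scatter), resting on no change at the digits printed from compound 2 to compound 3 (within the scatter). Compound 4 is estimated at 90%, between 80% and 98%.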

Compound 4, a percentage reported as activity, at one concentration (the size of the read-out at that concentration, not a potency): 92%
Compound 4: middle estimate off by 2 percentage points, on the low side, and the stated range covers the measured number.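

Hydrogen in place of methoxy on an aromatic carbon of the core of compound 1 gave no change at the digits printed from compound 1 to compound 4 (within the scatter) in this assay. Set beside the earlier step on the other core, the change carried over without a detectable difference: the same change on two cores in this assay, no change at the digits printed (within the scatter) from compound 2 to compound 3 and no change at the digits printed (within the scatter) from compound 1 to compound 4, 0 percentage points apart, within the scatter of two such steps. Going by these compounds alone, this shows only that two steps within the scatter agree at the one concentration tested; it does not show that the methoxy group is without effect at other concentrations or on any further core.

The compounds shown leave open what a hydroxyl, a fluorine or a longer chain such as ethoxy would do at this place. They also leave open whether removing a second methoxy group from the same ring would matter.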